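The source may hold more compounds than are shown below. What is called first, only, known or untested is meant among the compounds shown, and "the series" means these compounds.

Of the compounds shown here, two of a shared core have been measured so far. Compound 1, `CCn1ncnc1-c1ccccc1NCC1=NCCN1`, carries an ethyl group on the aromatic nitrogen of a five-membered aromatic ring with 3 nitrogen, and in a functional assay with Alpha-1B adrenergic receptor (Homo sapiens) as the target, read by calcium flux (on this read-out lower numbers stand for smaller maximal responses and higher numbers for larger maximal responses), compound 1 gives 94%. Compound 2, `CC(C)n1ncnc1-c1ccccc1NCC1=NCCN1`, carries an isopropyl group at the same place, and in this assay compound 2 gives 0%. Among the compounds with values here, the single step between them, a number 94 percentage points lower from compound 1 to compound 2 (beyond the scatter), is the only guide available here, and it leaves compound 2 standing at the lower of the two numbers.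

Compound 3, `CCCCn1ncnc1-c1ccccc1NCC1=NCCN1`, is the next member. It differs from compound 2 in one place: butyl in place of isopropyl on an aromatic nitrogen. The butyl group is a chain without branches, as the ethyl group of compound 1 is, but it is also longer than either group measured so far. Whether the outcome follows the unbranched ethyl of compound 1 or the isopropyl of compound 2 cannot be read from one step, so the expectation is broad. The step from compound 2 is expected to be a number 40 percentage points higher from compound 2 to compound 3 (beyond the scatter), and in this assay compound 3 is estimated at 40%, with a range from 0% to 95%.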

Compound 3, largest response reached (reported as maximal response), in percent of the reference or control that the assay uses: 83%
Compound 3: the middle estimate sits 43 percentage points below what was measured; low and high end bracket the measured number.
By their numbers in this assay, from the lowest: compound 2; then compound 3; then compound 1.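

On this aromatic nitrogen, adding carbon does not by itself remove the response in this assay: replacing isopropyl with butyl gives a number 83 percentage points higher from compound 2 to compound 3 (beyond the scatter) and so restores most of what compound 2 lacks, even though butyl is the larger of the two groups. Extending the unbranched chain from ethyl to butyl matters far less, giving a number 11 percentage points lower from compound 1 to compound 3 (beyond the scatter) as a real but modest step. Across these three compounds, the unbranched ethyl and butyl groups both give large responses, while the branched isopropyl group of compound 2 stands at 0% in this assay; no compound shown goes against this pattern, but it rests on a single branched group.

On these data alone, it remains open whether a longer chain such as hexyl keeps the response, whether a methyl group does, and whether other branched groups such as isobutyl or tert-butyl drop as far as isopropyl. Nothing available here accounts for why isopropyl and butyl differ so sharply at this position.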